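Series notes: dichlorophenyl for trifluoromethylphenyl on compound 3

The source may report more compounds than this note shows. Statements on the series, on what has been measured and on what is new or still open speak of the compounds shown alone.

Measured compounds in an ADME assay on L02 cells (Homo sapiens) for antiproliferative activity, read by MTT assay, with a stated time of 48 h; on this read-out higher numbers stand for weaker inhibition and lower numbers for stronger inhibition:
compound 1 `N#CC1=C(N)Oc2c(c3nc4ccccc4nc3c3ccccc23)C12C(=O)N(Cc1cnnn1-c1ccccc1Br)c1ccccc12`: compound 1 gives > 50000 nM, a limit of the assay and not a number.
compound 2 `N#CC1=C(N)Oc2c(c3nc4ccccc4nc3c3ccccc23)C12C(=O)N(Cc1cnnn1-c1cc(Cl)ccc1Cl)c1ccccc12`: compound 2 gives > 50000 nM, likewise a limit.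
compound 3 `N#CC1=C(N)Oc2c(N)cc3nc4ccccc4nc3c2C12C(=O)N(Cc1cnnn1-c1cccc(C(F)(F)F)c1)c1ccccc12`: compound 3 gives 38100 nM.

Among the measured compounds shown here, compound 3 thus holds the only number in this assay; the two other values sit at a limit (the limit of > 50000 nM in this assay, at which 2 of the 3 values shown sit). Compound 4 `N#CC1=C(N)Oc2c(N)cc3nc4ccccc4nc3c2C12C(=O)N(Cc1cnnn1-c1cc(Cl)ccc1Cl)c1ccccc12` differs from compound 3 by 2,5-dichlorophenyl in place of 3-(trifluoromethyl)phenyl on an aromatic nitrogen. For the measured compounds named here, the one measured step carrying this change, a step that the two limits leave unreadable from compound 1 to compound 2, lies between two limits and so has no readable size. No step beyond the usual scatter is therefore expected for compound 4: a 1.2-fold higher number from compound 3 to compound 4 (0.07 log units; within the scatter). Compound 4 is expected near 45000 nM, between 20000 nM and 100000 nM, with a fair chance that only a limit is reported.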

Compound 4, half-maximal inhibitory concentration: > 50000 nM
Compound 4 ended at the assay's limit; the forecaster's own chance of this, stated with the estimate: 50%; at least 1.1-fold (0.04 log units) between middle value and limit.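

In this assay, among the compounds shown here, 2,5-dichlorophenyl in place of 3-(trifluoromethyl)phenyl on the aromatic nitrogen gives an at least 1.3-fold higher number from compound 3 to compound 4 (0.11 log units; that floor lies within the scatter), the only step of this change with a readable floor, since the step between the two limits of compound 1 and compound 2 cannot be read. From the compounds shown here alone, the value of compound 4 is a limit of the assay, so the full size of the step remains unknown. Limits now make up most of the set: the limit of > 50000 nM in this assay, at which 3 of the 4 values shown sit.

Left open is how far compound 4 lies from compound 3. Also open, going by these compounds, is whether a phenyl bearing an amine or a carboxylic acid at this position would return a number rather than a limit.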